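Replacing 2,4-difluorophenyl with 2-chlorophenyl: what clearance to expect

A few compounds are considered here, and "the series" means these few. Any claim that something is new, unique, unknown or untested is made for them only; others in the source may bear on it.

Measured so far in an in vivo ADME assay on the whole organism (plasma) for pharmacokinetics, with Canis familiaris (Canis lupus familiaris) as the target; on this read-out lower numbers stand for slow clearance and higher numbers for fast clearance:
Compound 1 `CC(C)(C)N1CCC(c2cc(-c3ccc(F)cc3Cl)c3ccc(=O)n(-c4c(Cl)cccc4Cl)c3c2)CC1`: 26.8 mL/min/kg
Compound 2 `CC(C)(C)N1CCC(c2cc3c(ccc(=O)n3-c3c(Cl)cccc3Cl)c(-c3ccc(F)cc3F)n2)CC1`: 20.5 mL/min/kg

For the measured compounds named here, only two numbers are available in this assay, and they lie within the usual scatter of each other. Compound 2, at 20.5 mL/min/kg, therefore cannot be told apart from compound 1 on this read-out. The two compounds differ in more than one place, so their values do not isolate the effect of any single change.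

The next compound is compound 3 `CC(C)(C)N1CCC(c2cc3c(ccc(=O)n3-c3c(Cl)cccc3Cl)c(-c3ccccc3Cl)n2)CC1`. It carries 2-chlorophenyl in place of 2,4-difluorophenyl on an aromatic carbon, next to the ring nitrogen, and the rest of compound 2 is unchanged: 2-chlorophenyl in place of 2,4-difluorophenyl on an aromatic carbon.

Going by the values given here, no measured pair shows what this exchange does to clearance, so neither the size nor the direction of the step can be read from the data. The expectation is therefore modest, with no step beyond the scatter. The estimated change is a 1.1-fold higher number from compound 2 to compound 3 (0.03 log units; within the scatter). For compound 3 the expected clearance is 22 mL/min/kg, with an estimated range of 12 mL/min/kg to 38 mL/min/kg.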

Compound 3, clearance: 37.6 mL/min/kg
For compound 3 the middle estimate is 1.7-fold (0.23 log units) below the measured one; the range from low to high includes it.
By their numbers in this assay, from the lowest: compounds 2, 1 and 3 (each within the scatter of the next).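

In this assay, for the compounds shown here, putting 2-chlorophenyl in place of 2,4-difluorophenyl on the aromatic carbon next to the ring nitrogen gives a 1.8-fold higher number from compound 2 to compound 3 (0.26 log units; within the scatter), the first reading of a single change at this position. This one pair therefore shows that two fluorines can leave this aryl group and a chlorine can enter it without a step that stands clear of the differences seen between repeated measurements, although a single exchange says little about the position as a whole. Nothing at hand offers an explanation for this step, whatever its true size.

As far as these compounds go, it remains open which part of the exchange matters, the chlorine that enters or the fluorines that leave; 2-fluorophenyl, 4-fluorophenyl or plain phenyl at this place would begin to separate them. Also open, from the compounds shown here alone, is whether a group of another kind here, such as an amine or a carboxylic acid, would produce a step beyond the scatter, and whether this exchange would read the same with something other than the 1-(tert-butyl)piperidin-4-yl group on the core.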